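This account rests on a few compounds, and the source may have more. Where it says the series, first, only, none or still open, it means among the compounds named here.

Measured compounds:
compound 1 `Cc1ccc(-c2c(C)c(-c3ccc(C)c(C)c3)c(C(OC(C)(C)C)C(=O)O)c(C)c2NC(=O)Nc2ccccc2)cc1C` gives 8000 nM in an ADME assay on MT4 cells (Homo sapiens) for cytotoxicity, read by MTT assay, with a stated time of 4 days; on this read-out lower numbers stand for higher toxicity in this test and higher numbers for lower toxicity in this test
compound 2 `Cc1ccc(-c2c(C)c(-c3ccc(Cl)cc3)c(C(OC(C)(C)C)C(=O)O)c(C)c2NS(C)(=O)=O)cc1C` gives 26000 nM in this assay
compound 3 `Cc1ccc(-c2c(C)c(-c3ccccc3)c(C(OC(C)(C)C)C(=O)O)c(C)c2NS(C)(=O)=O)cc1C` gives > 50000 nM in this assay, which is a limit of the test, not a number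

Among these, compound 1 gives the lowest number, so it is the most cytotoxic of the three in this assay. Its nearest neighbour is compound 2, and that gap lies beyond the scatter.

Compound 4 `Cc1ccc(-c2c(C)c(-c3ccc(C)c(C)c3)c(C(OC(C)(C)C)C(=O)O)c(C)c2NS(C)(=O)=O)cc1C` has not yet been measured. It differs from compound 1 in one place: methylsulfonyl in place of phenylcarbamoyl on a nitrogen on an aromatic ring. In the same place, compound 2 and compound 3 already carry methylsulfonyl, and both give high numbers; compound 3 even sits at the limit of > 50000 nM in this assay, at which 1 of the 3 values shown sits. For the measured compounds named here, the single measured step, an at least 1.9-fold higher number from compound 2 to compound 3 (0.28 log units; that floor lies within the scatter), concerns a different part of the molecule and so says nothing directly about exchanging phenylcarbamoyl for methylsulfonyl. What the data do show is that both compounds carrying methylsulfonyl on that nitrogen are less toxic than compound 1 in this assay.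

Compound 4 is therefore expected to give a higher number than compound 1, the step being a 3.1-fold higher number from compound 1 to compound 4 (0.49 log units; beyond the scatter). The estimate for compound 4 in this assay is 25000 nM, with a range from 9000 nM to 60000 nM.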

Compound 4, half-maximal cytotoxic concentration: 15000 nM
Compound 4: middle estimate off by 1.7-fold (0.22 log units), on the high side; low and high end bracket the measured number.
By their numbers in this assay, from the lowest: compounds 1, 4 and 2 (each within the scatter of the next, the first and the last beyond it). At a limit, above all of these: compound 3.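

For the compounds shown here, compound 1 and compound 4 form the first direct pair for this change on the nitrogen, and the step is a 1.9-fold higher number from compound 1 to compound 4 (0.27 log units; within the scatter), so in this assay the exchange of phenylcarbamoyl for methylsulfonyl does not separate the two compounds. With methylsulfonyl held in place, the aromatic group on the other side of the comparison now matters: 3,4-dimethylphenyl in place of phenyl gives an at least 3.3-fold lower number from compound 3 to compound 4 (0.52 log units; beyond the scatter), while 3,4-dimethylphenyl in place of 4-chlorophenyl gives a 1.7-fold lower number from compound 2 to compound 4 (0.24 log units; within the scatter). The first of these two steps has only a floor, since compound 3 is read as a limit of the test and not as a number: the limit of > 50000 nM in this assay, at which 1 of the 4 values shown sits.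

The compounds shown leave open how an acetyl group or a longer chain such as propylsulfonyl would read on that nitrogen. They also leave open whether phenyl in place of 3,4-dimethylphenyl would shift the number in the same way with phenylcarbamoyl on the nitrogen, and what a methoxy group on that phenyl ring would do.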